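The compounds below may be only part of what the source reports. "The series", "measured", "known", "first", "only" and "open" are said of these compounds alone.

Compound 1 `CCCn1c(=O)[nH]c2nc(-c3ccc(S(=O)(=O)N4CCN(c5ccc(Br)cc5)CC4)cc3)[nH]c2c1=O` gives 0.0835 nM in an assay on CHO cells for displacement of a labelled ligand from adenosine receptor A2b (Homo sapiens), read by scintillation counting, with a stated time of 75 min, in the presence of a further agent that is not named here; on this read-out lower numbers stand for stronger inhibition and higher numbers for weaker inhibition
Compound 2 `CCCn1c(=O)[nH]c2nc(-c3ccc(S(=O)(=O)N4CCN(c5cccc(Br)c5)CC4)cc3)[nH]c2c1=O` gives 0.234 nM
Compound 3 `CCCn1c(=O)c2[nH]c(-c3ccc(S(=O)(=O)N4CCN(c5ccc(Cl)cc5)CC4)cc3)nc2n(CC)c1=O` gives 4.31 nM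

Compound 2 stands second highest of the three numbers in this assay; compound 1 lies nearest below it, compound 3 far above. Compound 4 `CCCn1c(=O)[nH]c2nc(-c3ccc(S(=O)(=O)N4CCN(Cc5ccc(Br)cc5)CC4)cc3)[nH]c2c1=O` differs from compound 2 by 4-bromobenzyl in place of 3-bromophenyl on an amine nitrogen in a ring. Going by the values given here, only one measured step bears on this: a 2.8-fold higher number from compound 1 to compound 2 (0.45 log units; beyond the scatter), which shows that bromine on the 4-position gave the lower number. Among the compounds with values here, compound 4 restores that 4-bromo pattern but also inserts a benzyl carbon, for which no measured step exists, so the expectation is uncertain. The step from compound 2 to compound 4 is expected to be a 1.3-fold higher number from compound 2 to compound 4 (0.11 log units; within the scatter). Compound 4 is therefore estimated at 0.3 nM, within a range from 0.05 nM to 2 nM.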

Compound 4, inhibition constant: 0.153 nM
Compound 4: middle estimate off by 2.0-fold (0.29 log units), on the high side; low and high end bracket the measured number.
By their numbers in this assay, from the lowest: compounds 1, 4 and 2 (each within the scatter of the next, the first and the last beyond it); then compound 3.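

In this assay, 4-bromobenzyl in place of 4-bromophenyl on the amine nitrogen gives a 1.8-fold higher number from compound 1 to compound 4 (0.26 log units; within the scatter) and so moves the number by no more than the scatter. Set against 3-bromophenyl, the same group gives a 1.5-fold lower number from compound 2 to compound 4 (0.18 log units; within the scatter) and so compound 4 cannot be separated from either compound 1 or compound 2, although those two lie apart beyond the scatter. The added benzyl carbon therefore leaves the number in the same range.

No measurement here offers a reason for these numbers. Going by these compounds, whether 3-bromobenzyl or a longer chain such as 4-bromophenethyl would stay in this range remains open.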